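Three dithiocarbamate chromones tested for antiproliferative activity

A few compounds are considered here, and "the series" means these few. Any claim that something is new, unique, unknown or untested is made for them only; others in the source may bear on it.

Measured compounds:
Compound 1 `O=c1c(SC(=S)N2CCCC2)coc2ccc(Cl)cc12` gives 24600 nM in a functional assay on LM7 cells (Homo sapiens) for antiproliferative activity, read by MTT assay, with a stated time of 72 h; on this read-out higher numbers stand for weaker inhibition and lower numbers for stronger inhibition.
Compound 2 `O=c1cc(CSC(=S)N2CCCCC2)oc2cc(Cl)ccc12` gives 13800 nM in this assay.
Compound 3 `O=c1cc(CSC(=S)N2CCCC2)oc2ccccc12` gives 40000 nM in this assay.

All three compounds carry a dithiocarbamate attached through a sulfur to a chromone core, and all three are weak inhibitors on this read-out. Compound 1 stands with its number separated from that of compound 3 and from that of compound 2 by gaps that lie within the usual scatter of repeated measurements, so the three results cannot be ranked against one another with confidence. Compound 2 and compound 3 also differ from compound 1 in more than one place, so they offer no clean comparison for any single change.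

Compound 4 `O=c1c(SC(=S)N2CCCCC2)coc2ccc(Cl)cc12` has not yet been measured. It differs from compound 1 in one place: piperidin-1-yl in place of pyrrolidin-1-yl on a thiocarbonyl carbon. Within the data shown here, there is no measured pair that isolates this change, so no computed step is available to lean on. Given how close the three measured numbers sit, the expectation for compound 4 in this assay is a step from compound 1 of a 1.4-fold lower number from compound 1 to compound 4 (0.14 log units; within the scatter), that is, no clear movement beyond the scatter in either direction. Compound 4 is accordingly estimated at 18000 nM, with a plausible range from 7000 nM to 45000 nM.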

Compound 4, half-maximal inhibitory concentration: > 25000 nM
Compound 4 was reported as a limit; the forecaster's own chance of this, stated with the estimate: 10%; middle value at least 1.3-fold (0.14 log units) away from the limit.
By their numbers in this assay, from the lowest: compounds 2, 1 and 3 (each within the scatter of the next, the first and the last beyond it).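

Among these compounds, this is the first comparison that changes only one place, the group on a thiocarbonyl carbon whose other neighbour is sulfur: piperidin-1-yl in place of pyrrolidin-1-yl gives an at least 1.0-fold higher number from compound 1 to compound 4 (0.00 log units; that floor lies within the scatter). In this assay compound 4 gives > 25000 nM, and this is a limit of the assay, not a number. The step therefore has a floor but no known upper end, so the swap shows no sign of stronger inhibition, while the true size of any loss stays unknown: the limit of > 25000 nM in this assay, at which 1 of the 4 values shown sits.

Among the compounds shown here, what a morpholine ring or an open-chain amine such as diethylamino would do on the same thiocarbonyl carbon remains open, since the two rings compared here are the only groups at this place on this core. The chlorine on the core of compound 1 also remains untested as a single change, and so does the link to the dithiocarbamate, since no pair of compounds shown isolates either one.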